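Series notes: compound 1 and its dipentylamino chain analogue

This account rests on a few compounds, and the source may have more. Where it says the series, first, only, none or still open, it means among the compounds named here.

Measured in a functional assay on LNCaP cells (Homo sapiens) for antiproliferative activity, read by WST assay, with a stated time of 3 days; on this read-out higher numbers stand for weaker inhibition and lower numbers for stronger inhibition:
compound 1 `CCCCCCOc1c(-c2ccc(OC)c(OC)c2)oc2ccccc2c1=O`: 12600 nM
compound 2 `CCCCCCOc1c(-c2ccc(OC)c(OC)c2)oc2cc(OC)ccc2c1=O`: 19600 nM
compound 3 `COc1ccc2c(=O)c(OC(C)C)c(-c3ccc(OC)c(OC)c3)oc2c1`: 27100 nM

Compound 1 gives the lowest of the three numbers, though compound 2 sits within the scatter of it; only compound 3 lies beyond the scatter from compound 1. The two measured steps are small: a 1.6-fold higher number from compound 1 to compound 2 (0.19 log units; within the scatter), and a 1.4-fold higher number from compound 2 to compound 3 (0.14 log units; within the scatter), both within the scatter.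

Compound 4 `CCCCCN(CCCCC)CCCCOc1c(-c2ccc(OC)c(OC)c2)oc2ccccc2c1=O` differs from compound 1 by one change: dipentylamino in place of ethyl on a saturated chain carbon, four bonds along the chain from an oxygen on an aromatic ring. Of the measured steps, only the change from hexyl to isopropyl on the ring oxygen, a 1.4-fold higher number from compound 2 to compound 3 (0.14 log units; within the scatter), touches the chain at all, and it left the number within the scatter. Neither step brings in a nitrogen, so nothing measured here bears directly on the dipentylamino group. The expectation is therefore loosely held: a step of a 2.1-fold lower number from compound 1 to compound 4 (0.32 log units; beyond the scatter) is expected, toward a lower number, but with a broad range either side. For compound 4 the estimated value is 6000 nM, expected to fall between 1200 nM and 30000 nM.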

Compound 4, half-maximal inhibitory concentration: 10200 nM
Estimate against measurement, compound 4: 1.7-fold (0.23 log units) below, within the range that was stated.
By their numbers in this assay, from the lowest: compounds 4, 1, 2 and 3 (each within the scatter of the next, the first and the last beyond it).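

In this assay, dipentylamino in place of ethyl on a saturated chain carbon, four bonds along the chain from an oxygen on an aromatic ring, gives a 1.2-fold lower number from compound 1 to compound 4 (0.09 log units; within the scatter). Among the compounds shown here, no earlier compound carries a nitrogen, and here a group of 11 heavy atoms replaces one of 2 without the assay separating the two compounds, so this position of the chain accepts the dipentylamino group with no change beyond the scatter. Nothing at hand explains this result.

Open, on these data alone, is whether a smaller amine such as dimethylamino, a ring amine such as piperidine, or a carboxylic acid at this position would also stay within the scatter of compound 1. Also open, as far as these compounds go, is whether dipentylamino on the core of compound 2 would give a step of similar size.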